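The source may hold more compounds than are shown below. What is called first, only, known or untested is meant among the compounds shown, and "the series" means these compounds.

Compound 1 `COc1ccc(C2CC(c3ccccc3)=NN2C2=NC(=O)/C(=C3\C(=O)Nc4ccc(Br)cc43)S2)cc1` gives 3630 nM in a functional assay on cells (Cancer cell lines, Homo sapiens) for cytotoxicity, read by sulforhodamine B assay, with a stated time of 48 h; on this read-out lower numbers stand for stronger inhibition of growth and higher numbers for weaker inhibition of growth; compound 2 `COc1ccc(C2=NN(C3=NC(=O)/C(=C4\C(=O)Nc5ccc(Br)cc54)S3)C(c3ccc(OC)cc3)C2)cc1` gives 32500 nM; compound 3 `O=C1N=C(N2N=C(c3ccccc3)CC2c2ccc(Cl)cc2)S/C1=C1/C(=O)Nc2ccccc21` gives 650 nM.

Compound 3 has the lowest of the three numbers, and its nearest neighbour is compound 1. The difference between the cores of compound 3 and compound 1 is not broken down here. From compound 1 to compound 2 the change is methoxy in place of hydrogen on an aromatic carbon, and this brings a 9.0-fold higher number from compound 1 to compound 2 (0.95 log units; beyond the scatter).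

Compound 4 `COc1ccc(C2=NN(C3=NC(=O)/C(=C4\C(=O)Nc5ccccc54)S3)C(c3ccc(Cl)cc3)C2)cc1` is not yet measured. It differs from compound 3 by methoxy in place of hydrogen on an aromatic carbon, which is the same change as that from compound 1 to compound 2, at a place described in the same words. Among the measured compounds shown here, the only guide to its effect is the single step between compound 1 and compound 2, so the expectation rests on one example on a related core. Compound 4 is therefore expected to show a weaker result than compound 3, with an estimated step of a 6.9-fold higher number from compound 3 to compound 4 (0.84 log units; beyond the scatter), because the comparable step gave a 9.0-fold higher number from compound 1 to compound 2 (0.95 log units; beyond the scatter). The estimate for compound 4 is 4500 nM, with a range from 1300 nM to 15000 nM.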

Compound 4, concentration for total growth inhibition: 100000 nM
Beside the measured number, compound 4's estimate is 22-fold (1.35 log units) below it; the measured number lies above the stated range.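

In this assay, the change from phenyl to 4-methoxyphenyl brings a 150-fold higher number from compound 3 to compound 4 (2.19 log units; beyond the scatter), and the number rises in the same direction as on the earlier pair, so on both cores shown the methoxy group goes with weaker inhibition of growth. The direction carries across these two cores, but the size of the step does not: the same change on two cores in this assay, a 9.0-fold higher number (0.95 log units; beyond the scatter) from compound 1 to compound 2 and a 150-fold higher number (2.19 log units; beyond the scatter) from compound 3 to compound 4, 17-fold (1.24 log units) apart, beyond the scatter of two such steps The two pairs differ from each other in more than one place, so the data do not show which of those differences goes with the larger step, and two pairs give no rule for the whole series.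

The compounds shown leave open whether a hydroxyl, an amine or a carboxylic acid in place of the methoxy would bring a step of similar direction and size. They also leave open how the same methoxy change would read on two cores that differ from each other in only one place.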